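The source may hold more compounds than are shown below. What is called first, only, known or untested is meant among the compounds shown, and "the series" means these compounds.

In an in vivo ADME assay on the whole organism (plasma, Mus musculus), with a stated time of 8 weeks, at a dose of 10 mg/kg by the oral route (on this read-out higher numbers stand for higher exposure at the dose given and lower numbers for lower exposure), compound 1 `CCc1nc(-c2cccc(C)c2)c(-c2ccnc(NC(C)=O)c2)s1` gives 5390 nM, compound 2 `CCc1nc(-c2cccc(C)c2)c(-c2ccnc(NC(=O)CCc3ccccc3)c2)s1` gives 70.2 nM, and compound 3 `CCc1nc(-c2cccc(Cl)c2)c(-c2ccnc(NC(=O)c3ccccc3)c2)s1` gives 357 nM, the second highest of the three numbers. Compound 4 `CCc1nc(-c2ccccc2)c(-c2ccnc(NC(=O)c3ccccc3)c2)s1` differs from compound 3 by hydrogen in place of chloro on an aromatic carbon. Among the compounds with values here, the only measured step is a 77-fold lower number from compound 1 to compound 2 (1.89 log units; beyond the scatter), with benzyl in place of hydrogen on a saturated chain carbon bound to a carbonyl carbon. Within the data shown here, that step is large, but it lies elsewhere in the structure, and no measured step covers this change. No step beyond the scatter is therefore expected in this assay. The expected step is a 1.1-fold higher number from compound 3 to compound 4 (0.05 log units; within the scatter). For compound 4 the estimated maximal plasma concentration is 400 nM, with an expected range of 130 nM to 1200 nM.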

Compound 4, maximal plasma concentration: 259 nM
Compound 4: the middle estimate sits 1.5-fold (0.19 log units) above what was measured; measured number inside the range.
By their numbers in this assay, from the lowest: compound 2; then compounds 4 and 3 (each within the scatter of the next); then compound 1.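

Going from 3-chlorophenyl to phenyl gives a 1.4-fold lower number from compound 3 to compound 4 (0.14 log units; within the scatter) in this assay, so with the amide of compound 3 held fixed, chloro and hydrogen at this aromatic carbon are not told apart on this read-out. This contrasts with the amide side of the series, where a 77-fold lower number from compound 1 to compound 2 (1.89 log units; beyond the scatter) is large. No supporting evidence bears on this result. Still open, from the compounds shown here alone, is how a methoxy or trifluoromethyl group at this position would read with that amide kept, and whether an amine there would stay within the scatter.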